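Chloro to Azido on the Side Chain of Compound 2

A few compounds are considered here, and "the series" means these few. Any claim that something is new, unique, unknown or untested is made for them only; others in the source may bear on it.

Compound 1 `C=C1/C=C/C(=O)/C(CO)=C\C[C@](C)(CCC=C(C)C)/C=C/[C@H]1OC(=O)C=C(C)C`: 2810 nM
Compound 2 `CC(C)=CCC[C@]1(C)/C=C/[C@@H](OC(=O)C=C(C)C)[C@](C)(O)/C=C/C(=O)/C(CCl)=C\C1`: 160 nM
Compound 3 `CC(C)=CCC[C@]1(C)/C=C/[C@@H](OC(=O)C=C(C)C)[C@](C)(O)/C=C/C(=O)/C(C[Si](c2ccccc2)(c2ccccc2)C(C)(C)C)=C\C1`: 14400 nM

Of the compounds shown here, three have been measured in a functional assay on HL-60 cells (Homo sapiens) for antiproliferative activity, read by MTT assay, with a stated time of 48 h; on this read-out higher numbers stand for weaker inhibition and lower numbers for stronger inhibition. Compound 2 gives the lowest number of the three and is the most potent, since its gap to compound 1 and its larger gap to compound 3 both lie beyond the scatter of this assay. Compound 4 `CC(C)=CCC[C@]1(C)/C=C/[C@@H](OC(=O)C=C(C)C)[C@](C)(O)/C=C/C(=O)/C(CN=[N+]=[N-])=C\C1` has not yet been measured. It differs from compound 2 by a single change: azido in place of chloro on a saturated chain carbon bound to a double-bonded ring carbon. Going by the values given here, no measured pair shows this same change, so there is no direct precedent for the size of the step. Compound 4 is expected to give a somewhat higher number than compound 2, a step of a 5.6-fold higher number from compound 2 to compound 4 (0.75 log units; beyond the scatter) that may exceed the scatter. Compound 4 is therefore estimated at 900 nM, with a range from 200 nM to 4000 nM.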

Compound 4, half-maximal inhibitory concentration: 910 nM
For compound 4 the middle estimate is 1.0-fold (0.00 log units) below the measured one; the range from low to high includes it.
By their numbers in this assay, from the lowest: compound 2; then compound 4; then compound 1; then compound 3.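

In this assay, going by these compounds alone, the change from chloromethyl to azidomethyl gives a 5.7-fold higher number from compound 2 to compound 4 (0.75 log units; beyond the scatter) and is the first measured step at this position, on a saturated chain carbon bound to a double-bonded ring carbon. It shows that the position responds to this exchange, with the chloro group giving the stronger inhibition of the pair, although the step is modest. No measurement at hand accounts for the difference. The compounds shown leave open how a bromo group or an amine on this carbon would compare with chloro and azido.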